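Propyl to isopropyl on the oxygen: working notes

This account rests on a few compounds, and the source may have more. Where it says the series, first, only, none or still open, it means among the compounds named here.

Measured in a functional assay on the whole organism for inhibition, with Rattus norvegicus as the target, read by paw edema, with stated times of 1 h and 3 h (on this read-out higher numbers stand for an effect only at larger amounts of compound and lower numbers for an effect already at smaller amounts), so far:
compound 1 `COC(=O)CO/N=C(\C)c1ccc(Cl)cc1` gives 24 mg/kg
compound 2 `C/C(=N\OCC(N)=O)c1ccc(Cl)cc1` gives 24 mg/kg
compound 3 `CCCOC(=O)CO/N=C(\C)c1ccc(Cl)cc1` gives 14 mg/kg

Compound 3 is not separated from the other two compounds on these numbers. The gaps to it are a 1.7-fold lower number from compound 1 to compound 3 (0.23 log units; within the scatter) and a 1.7-fold lower number from compound 2 to compound 3 (0.23 log units; within the scatter) and neither leaves the scatter.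

Compound 4 `C/C(=N\OCC(=O)OC(C)C)c1ccc(Cl)cc1` has the same atoms as compound 3, joined differently: isopropyl in place of propyl on an oxygen next to a carbonyl group with isopropyl in place of propyl on an oxygen next to a carbonyl group. Within the data shown here, the steps that bear on this change are those that alter the group on the same carbonyl carbon. Besides the two gaps above, these include no change at the digits printed from compound 1 to compound 2 (within the scatter) and that step also stays within the scatter. Among the measured compounds shown here, no measured compound carries isopropyl, so the series offers no direct reading of this group. With steps this small across compound 1, compound 2 and compound 3, the expected step is a 1.1-fold higher number from compound 3 to compound 4 (0.06 log units; within the scatter) and no change beyond the scatter is expected in this assay on this evidence. The value of compound 4 is estimated at 16 mg/kg (expected range 8 mg/kg to 30 mg/kg).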

Compound 4, dose for half-maximal effect: 50 mg/kg
Beside the measured number, compound 4's estimate is 3.1-fold (0.49 log units) below it, and the stated range ends below it.
By their numbers in this assay, from the lowest: compounds 3, 1 and 2 (each within the scatter of the next); then compound 4.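

In this assay, among these compounds, the group on the oxygen next to the carbonyl group matters more than the earlier compounds suggested: the same atoms joined as isopropyl rather than propyl give a 3.6-fold higher number from compound 3 to compound 4 (0.55 log units; beyond the scatter) and so leave the scatter, which no step among compound 1, compound 2 and compound 3 does. The two other steps to this group also leave it, with a 2.1-fold higher number from compound 1 to compound 4 (0.32 log units; beyond the scatter) for isopropyl in place of methyl on that oxygen and a 2.1-fold higher number from compound 2 to compound 4 (0.32 log units; beyond the scatter) for isopropoxy in place of amino on the carbonyl carbon, so compound 4 stands apart from all three as the compound that needs the largest amount for its effect, although each of these steps is modest. No supporting data bear on why isopropyl behaves differently from propyl here.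

Among the compounds shown here, compound 4 is the only compound with isopropyl, so one step cannot show whether the loss extends to a tert-butyl or cyclopentyl ester. From the compounds shown here alone, how a free carboxylic acid or a longer chain such as butyl would read at this carbonyl carbon also remains open.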